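Removing the tert-butoxycarbonyl group from compound 3

The source may hold more compounds than are shown below. What is called first, only, known or untested is meant among the compounds shown, and "the series" means these compounds.

Compound 1 `CCN(CC)c1ccc(NC(=O)CCCCCCC(=O)NO)cc1`: 2700 nM
Compound 2 `CCN(CC)CCCNC(=O)c1ccc(NC(=O)CCCCCCC(=O)NO)cc1`: 34000 nM
Compound 3 `CC(C)(C)OC(=O)N1CCC(NC(=O)c2ccc(NC(=O)CCCCCCC(=O)NO)cc2)CC1`: 2500 nM

All three compounds were measured in a functional assay on HL-60 cells (Homo sapiens) for inhibition, read by ATP content, with a stated time of 72 h; on this read-out lower numbers stand for stronger inhibition and higher numbers for weaker inhibition. Compound 3, at 2500 nM, has the lowest of the three numbers, but it lies within the scatter of compound 1. Compound 2 has a number beyond the scatter above that of compound 3, which means weaker inhibition.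

The next compound is compound 4 `O=C(CCCCCCC(=O)Nc1ccc(C(=O)NC2CCNCC2)cc1)NO`. It differs from compound 3 by hydrogen in place of tert-butoxycarbonyl on an amine nitrogen in a ring. Within the data shown here, no measured pair differs in one place only, so the size of this step in this assay cannot be read directly from the data. The nearest guides point in different directions. Compound 2 also has no tert-butoxycarbonyl and gives 34000 nM. Compound 1 also has none, yet gives 2700 nM, and so goes against any simple pattern. On balance, a step beyond the scatter towards weaker inhibition is expected, though with wide uncertainty. The estimated change is a 4.8-fold higher number from compound 3 to compound 4 (0.68 log units; beyond the scatter). For compound 4 the expected value is 12000 nM, with an estimated range from 3000 nM to 40000 nM.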

Compound 4, half-maximal inhibitory concentration: 100000 nM
Estimate against measurement, compound 4: 8.3-fold (0.92 log units) below, and the stated range ends below it.
By their numbers in this assay, from the lowest: compounds 3 and 1 (each within the scatter of the next); then compound 2; then compound 4.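

Hydrogen in place of tert-butoxycarbonyl on an amine nitrogen in a ring gives in this assay a 40-fold higher number from compound 3 to compound 4 (1.60 log units; beyond the scatter) as a large step, the first read directly at this position. Compound 4 also stands apart from the other two compounds: piperidin-4-yl in place of 3-(diethylamino)propyl on an amide-type nitrogen gives a 2.9-fold higher number from compound 2 to compound 4 (0.47 log units; beyond the scatter) as a modest step, while (piperidin-4-yl)carbamoyl in place of diethylamino on an aromatic carbon gives a 37-fold higher number from compound 1 to compound 4 (1.57 log units; beyond the scatter) as a large step, which leaves compound 4 with the weakest inhibition of the four in this assay on these numbers. Nothing measured here accounts for the size of these steps.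

The compounds shown leave open whether a smaller group on this ring nitrogen, such as methyl, acetyl or methoxycarbonyl, would give numbers nearer to that of compound 3 or to that of compound 4. They also leave open whether the step from tert-butoxycarbonyl to hydrogen would keep its size with a longer chain in the shared core.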